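Swapping methylamino for piperidin-1-yl on compound 2

The source may report more compounds than this note shows. Statements on the series, on what has been measured and on what is new or still open speak of the compounds shown alone.

In an ADME assay on microsomes from liver (Mus musculus) for metabolic stability, read by HPLC, with a stated time of 4 h (on this read-out lower numbers stand for slow clearance and higher numbers for fast clearance), compound 1 `Nc1nc2cc(N3CCCCC3)ccc2cc1-c1cc(Cl)cc(Cl)c1` gives 460 mL/min/kg while compound 2 `CNc1ccc2cc(-c3cn(C)c4ccccc34)c(N)nc2c1` gives 41 mL/min/kg as the lower of the two numbers, a gap beyond the usual scatter. Compound 3 `Cn1cc(-c2cc3ccc(N4CCCCC4)cc3nc2N)c2ccccc21` differs from compound 2 in one place, with piperidin-1-yl in place of methylamino on an aromatic carbon as the count: piperidin-1-yl in place of methylamino on an aromatic carbon. Among the measured compounds shown here, no measured pair shows this swap alone. Compound 1 also carries piperidin-1-yl and its 460 mL/min/kg points upward. The expected change, a 4.4-fold higher number from compound 2 to compound 3 (0.64 log units; beyond the scatter) as estimated here, is a rise beyond the scatter. Compound 3 is estimated at 180 mL/min/kg with 70 mL/min/kg to 480 mL/min/kg as its expected range.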

Compound 3, clearance: 95 mL/min/kg
Compound 3: the middle estimate sits 1.9-fold (0.28 log units) above what was measured; measured number inside the range.
By their numbers in this assay, from the lowest: compound 2; then compound 3; then compound 1.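

Among the compounds shown here, at this position, piperidin-1-yl in place of methylamino gives a 2.3-fold higher number from compound 2 to compound 3 (0.36 log units; beyond the scatter) in this assay and so isolates this swap for the first time. The step is modest, yet it shows that this change alone goes with faster clearance in this pair. Nothing available explains the rise. For the compounds shown here, whether the same step would appear on another core remains open, since only this one pair shows it. A dimethylamino group or a morpholin-4-yl ring here could help separate the effect of group size from that of the hydrogen-bond donor that methylamino carries.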